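This account rests on a few compounds, and the source may have more. Where it says the series, first, only, none or still open, it means among the compounds named here.

- Compound 1 `Cc1nc2cc(OC[C@H](O)CN3CCN(CC(=O)Nc4c(C)cccc4C)C[C@H]3C)ccc2s1`: 2000 nM
- Compound 2 `Cc1nc2cc(OC[C@@H](O)CN3CCN(CC(=O)Nc4c(C)cccc4C)C[C@H]3C)ccc2s1`: 10000 nM

Going by the values given here, in a functional assay (mitochondria) for inhibition, with Rattus norvegicus as the target (on this read-out lower numbers stand for stronger inhibition and higher numbers for weaker inhibition), compound 2 gives 10000 nM, the higher of the two numbers so far and therefore the weaker inhibition. The next compound, compound 3 `Cc1nc2cc(OC[C@@H](O)CN3CCN(CC(=O)Nc4c(C)cccc4C)C[C@@H]3C)ccc2s1`, is built from the same atoms and bonds. the two compounds have the same atoms and bonds and differ only in configuration as drawn: 1 of 2 stereo elements differ; a stereocentre at a saturated ring carbon is drawn R in compound 2 and S in compound 3 Only the spatial arrangement at that ring carbon changes.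

Among the compounds with values here, only one measured step bears on this: a 5.0-fold higher number from compound 1 to compound 2 (0.70 log units; beyond the scatter). It shows that configuration alone can shift this read-out, because of the fact that compounds 1 and 2 differ only in the configuration as drawn. That step, however, concerns a stereocentre at a saturated chain carbon and not the ring carbon, so it offers a guide to size but none to direction. A change of similar or smaller size is therefore plausible in this assay, and it could go either way. Within the data shown here, with compound 2 at the top of the numbers so far, a slight lean towards stronger inhibition seems reasonable. The expected change is small: a 1.4-fold lower number from compound 2 to compound 3 (0.15 log units; within the scatter). Compound 3 is estimated at 7000 nM, with an expected range from 2000 nM to 25000 nM.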

Compound 3, half-maximal inhibitory concentration: 5000 nM
For compound 3 the middle estimate is 1.4-fold (0.15 log units) above the measured one, within the range that was stated.
By their numbers in this assay, from the lowest: compound 1; then compounds 3 and 2 (each within the scatter of the next).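

At the ring carbon, inversion gives a 2.0-fold lower number from compound 2 to compound 3 (0.30 log units; within the scatter) in this assay, so with the chain carbon drawn S, the configuration at this ring carbon has no effect that can be told apart from ordinary repeat variation. Inverting both stereocentres gives the mirror-image pair and a 2.5-fold higher number from compound 1 to compound 3 (0.40 log units; beyond the scatter), and configuration alone must account for this gap, because nothing else separates the two compounds: the fact that compounds 1 and 3 differ only in the configuration as drawn. Among these three compounds, the clear single-centre step is therefore the one at the chain carbon, a 5.0-fold higher number from compound 1 to compound 2 (0.70 log units; beyond the scatter), although that step was read with the ring carbon drawn R, whereas the ring step was read with the chain carbon drawn S.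

Whether the ring carbon would matter more with the chain carbon drawn R remains open, as that combination of R at the chain carbon and S at the ring carbon lies outside the compounds shown. Also open, going by these compounds, is how the read-out would respond to a change of atoms rather than of configuration, such as an ethyl group in place of the methyl on the ring carbon, or a methoxy group in place of the hydroxyl on the chain carbon.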